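Chloro for methyl on a shared spiro core

The source may report more compounds than this note shows. Statements on the series, on what has been measured and on what is new or still open speak of the compounds shown alone.

Measured compounds and their values:
compound 1, `Cc1ccc2[nH]c3c(c2c1)CC[C@]1(C3=O)[C@@H](c2ccccc2)[C@@H](c2ccccc2)N[C@@]12C(=O)Nc1ccccc12`: 19000 nM
compound 2, `O=C1Nc2ccccc2[C@]12N[C@H](c1ccccc1)[C@H](c1ccccc1)[C@@]21CCc2c([nH]c3ccc(Cl)cc23)C1=O`: 18000 nM
compound 3, `COc1ccc([C@H]2[C@@H](c3ccccc3)N[C@@]3(C(=O)Nc4ccccc43)[C@]23CCc2c([nH]c4ccc(C)cc24)C3=O)cc1`: 18000 nM

Three compounds were tested in a functional assay on MCF7 cells (Homo sapiens) for antiproliferative activity, read by MTT assay, with a stated time of 48 h; a lower number here means a stronger inhibitor, a higher number a weaker inhibitor. Compound 1 gives 19000 nM in this assay. Compound 2 differs from compound 1 by chloro in place of methyl on an aromatic carbon, and this step gives a 1.1-fold lower number from compound 1 to compound 2 (0.02 log units; within the scatter). Compound 3 differs from compound 1 by methoxy in place of hydrogen on an aromatic carbon, and this step gives a 1.1-fold lower number from compound 1 to compound 3 (0.02 log units; within the scatter). Compound 3 thus stands level with compound 2 at the digits recorded, and all three values lie within the usual scatter of one another, so no ordering among them can be read from these numbers.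

Compound 4, `COc1ccc([C@H]2[C@@H](c3ccccc3)N[C@@]3(C(=O)Nc4ccccc43)[C@]23CCc2c([nH]c4ccc(Cl)cc24)C3=O)cc1`, has not yet been measured in this assay. It differs from compound 3 by chloro in place of methyl on an aromatic carbon. This is the same change that turns compound 1 into compound 2, made on a core that differs from the core of compound 1 by methoxy in place of hydrogen on an aromatic carbon. The place of the change is described in the same words for both pairs.

Compound 4 is expected to show a step of a 1.1-fold lower number from compound 3 to compound 4 (0.02 log units; within the scatter), set beside the earlier step of a 1.1-fold lower number from compound 1 to compound 2 (0.02 log units; within the scatter). Among the compounds with values here, this expectation rests on the earlier pair because a 1.1-fold lower number from compound 1 to compound 2 (0.02 log units; within the scatter) was within the scatter, and the only other change seen, a 1.1-fold lower number from compound 1 to compound 3 (0.02 log units; within the scatter), was also within the scatter. Compound 4 is therefore estimated at 17000 nM in this assay, with a range from 8500 nM to 34000 nM.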

Compound 4, half-maximal inhibitory concentration: 19000 nM
The estimate for compound 4 lay 1.1-fold (0.05 log units) below the measured number; the range from low to high includes it.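

In this assay, chloro in place of methyl on an aromatic carbon, now made on the core that carries the methoxy group, gives a 1.1-fold higher number from compound 3 to compound 4 (0.02 log units; within the scatter), and the comparison with the same change on the core of compound 1 finds no difference: the same change on two cores in this assay, a 1.1-fold lower number (0.02 log units; within the scatter) from compound 1 to compound 2 and a 1.1-fold higher number (0.02 log units; within the scatter) from compound 3 to compound 4, 1.1-fold (0.05 log units) apart, within the scatter of two such steps. Methoxy in place of hydrogen on an aromatic carbon, carried to the core that carries the chloro group, gives a 1.1-fold higher number from compound 2 to compound 4 (0.02 log units; within the scatter), and this change also reads alike on its two cores: the same change on two cores in this assay, a 1.1-fold lower number (0.02 log units; within the scatter) from compound 1 to compound 3 and a 1.1-fold higher number (0.02 log units; within the scatter) from compound 2 to compound 4, 1.1-fold (0.05 log units) apart, within the scatter of two such steps. Within the data shown here, this shows that neither change moves the number beyond the scatter on either core, but since no step of measurable size exists here, it does not show that a change with a real effect would carry from one core to another.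

The compounds shown leave open whether an amine or a carboxylic acid in place of the chloro or methyl group, or a longer chain in place of the methoxy group, would give a step beyond the scatter. They also leave open whether the two changes would behave alike on these cores in cells other than those of this assay.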